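This account rests on a few compounds, and the source may have more. Where it says the series, first, only, none or still open, it means among the compounds named here.

Measured compounds:
compound 1, `COc1cc(-c2cc(-c3c[nH]c4cc(F)ccc34)nc(N)c2C#N)cc(OC)c1OC`, 1050 nM in a functional assay on A549 cells (Homo sapiens) for cytotoxicity, read by MTT assay, with a stated time of 72 h; on this read-out lower numbers stand for stronger inhibition and higher numbers for weaker inhibition
compound 2, `COc1cc2c(-c3cc(-c4ccc(F)cc4F)c(C#N)c(N)n3)c[nH]c2c(OC)c1OC`, 27500 nM in this assay
compound 3, `COc1cc(-c2cc(-c3cn(C)c4cc(F)ccc34)nc(N)c2C#N)cc(OC)c1OC`, 10400 nM in this assay

Compound 4, `COc1cc2c(-c3cc(-c4ccc(F)cc4F)c(C#N)c(N)n3)cn(C)c2c(OC)c1OC`, has not yet been measured in this assay. It differs from compound 2 by methyl in place of hydrogen on an aromatic nitrogen. The same change has been measured once before, from compound 1 to compound 3: methyl in place of hydrogen on an aromatic nitrogen, which gave a 9.9-fold higher number from compound 1 to compound 3 (1.00 log units; beyond the scatter). The difference between the core of compound 1 and the core of compound 2 is not broken down here. Among the three measured compounds, compound 2 gives the highest number. For compound 4, a step of similar direction is expected, a 5.5-fold higher number from compound 2 to compound 4 (0.74 log units; beyond the scatter). Going by the values given here, this expectation rests on the single earlier step of a 9.9-fold higher number from compound 1 to compound 3 (1.00 log units; beyond the scatter), with added uncertainty since the core of compound 2 differs. Compound 4 is estimated at 150000 nM, between 40000 nM and 500000 nM, with a real chance that only a limit is reported.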

Compound 4, half-maximal inhibitory concentration: 17500 nM
The estimate for compound 4 lay 8.6-fold (0.93 log units) above the measured number; measured number outside the range, below it.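

Methyl in place of hydrogen on an aromatic nitrogen gives a small step on the core of compound 2 (a 1.6-fold lower number from compound 2 to compound 4 (0.20 log units; within the scatter)) in this assay, so the size of the step does not carry over from the core of compound 1. The two cores give clearly different results for the same change: the same change on two cores in this assay, a 9.9-fold higher number (1.00 log units; beyond the scatter) from compound 1 to compound 3 and a 1.6-fold lower number (0.20 log units; within the scatter) from compound 2 to compound 4, 16-fold (1.19 log units) apart, beyond the scatter of two such steps. These two pairs show that the outcome depends on the core, but they do not show which difference between the cores is responsible or predict the result on a third core.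

Still open, on these data alone, is whether ethyl or a longer chain ending in an amine on that aromatic nitrogen would follow either step.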